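Adding an acetamido group to compound 2

The source may report more compounds than this note shows. Statements on the series, on what has been measured and on what is new or still open speak of the compounds shown alone.

Compound 1 `COC1=CC(=O)c2c(c(COCc3ccccc3)c(C)n2C)C1=O`: 410000 nM
Compound 2 `COC1=CC(=O)c2c(c(COc3ccccc3)c(C)n2C)C1=O`: 700 nM

In a functional assay on V79-379A cells (Cricetulus griseus) for cytotoxicity, read by MTT assay, in the presence of a further agent that is not named here (on this read-out lower numbers stand for stronger inhibition and higher numbers for weaker inhibition), compound 2 has the lower of the two numbers. Compound 3 `COC1=CC(=O)c2c(c(COc3cccc(NC(C)=O)c3)c(C)n2C)C1=O` differs from it by acetamido in place of hydrogen on an aromatic carbon, meta to a large group. Among the compounds with values here, the only measured step, a 590-fold lower number from compound 1 to compound 2 (2.77 log units; beyond the scatter), is large, but it is phenyl in place of benzyl on an oxygen on a saturated carbon, a different change. Within the data shown here, it therefore sets no size here, and no step clearly beyond the scatter is expected, with a slight lean towards a higher number. The expected result is a 1.4-fold higher number from compound 2 to compound 3 (0.15 log units; within the scatter). The estimate for compound 3 is 1000 nM, with an expected range of 200 nM to 6000 nM.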

Compound 3, half-maximal inhibitory concentration: 40 nM
Estimate against measurement, compound 3: 25-fold (1.40 log units) above; the measured number lies below the stated range.
By their numbers in this assay, from the lowest: compound 3; then compound 2; then compound 1.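

In this assay, acetamido in place of hydrogen on an aromatic carbon, meta to a large group, gives an 18-fold lower number from compound 2 to compound 3 (1.24 log units; beyond the scatter) and so this ring position responds strongly to substitution. Within the data shown here, the earlier compounds showed only that the group on the oxygen matters, whereas this step shows that a substituent on the phenyl ring itself can also move the number well beyond the scatter. No measurement at hand explains this step. The compounds shown leave open whether an amine or a methoxy group at this place would give a similar number. They also leave open whether acetamido elsewhere on the ring would do the same.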